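A Chloro for a Hydroxy on the Urea Aryl

A few compounds are considered here, and "the series" means these few. Any claim that something is new, unique, unknown or untested is made for them only; others in the source may bear on it.

compound 1 `COc1cc(NC(C)CCCNC(=O)Nc2ccc(O)cc2)c2ncccc2c1`: 23000 nM
compound 2 `COc1cc(NC(C)CCCNC(=O)NNC(=O)Nc2cccc(Cl)c2)c2ncccc2c1`: 81000 nM

In a functional assay on CCRF-CEM cells (Homo sapiens) for inhibition, read by MTT assay, with a stated time of 72 h (on this read-out lower numbers stand for stronger inhibition and higher numbers for weaker inhibition), compound 1 stands lowest of the two numbers, with compound 2 the nearer neighbour: a 3.5-fold higher number from compound 1 to compound 2 (0.55 log units; beyond the scatter). Compound 3 `COc1cc(NC(C)CCCNC(=O)Nc2ccc(Cl)cc2)c2ncccc2c1` differs from compound 1 by chloro in place of hydroxy on an aromatic carbon. Among the measured compounds shown here, the only measured step alters a different part of the molecule and does not bear on this swap, so there is no measured guide to it. A step within the scatter is therefore expected, a 1.2-fold lower number from compound 1 to compound 3 (0.06 log units; within the scatter). Compound 3 is estimated at 20000 nM, between 6000 nM and 65000 nM.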

Compound 3, half-maximal inhibitory concentration: 24000 nM
The estimate for compound 3 lay 1.2-fold (0.08 log units) below the measured number, within the range that was stated.
By their numbers in this assay, from the lowest: compounds 1 and 3 (each within the scatter of the next); then compound 2.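

In this assay, chloro in place of hydroxy on an aromatic carbon para to a large group gives a 1.0-fold higher number from compound 1 to compound 3 (0.02 log units; within the scatter) and so leaves the number unmoved, even though the hydrogen-bond donor and acceptor of the hydroxy are lost. The change on the amide-type nitrogen, by contrast, stays beyond the scatter with chloro on the aryl, as a 3.4-fold lower number from compound 2 to compound 3 (0.53 log units; beyond the scatter) shows. Nothing available explains either step. As far as these compounds go, whether an amine or a carboxylic acid on the same aromatic carbon would also leave the number in place stays open.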